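This account rests on a few compounds, and the source may have more. Where it says the series, first, only, none or still open, it means among the compounds named here.

Among the compounds with values here, in a functional assay on WM164 cells (Homo sapiens) for antiproliferative activity, read by sulforhodamine B assay, with a stated time of 48 h (on this read-out lower numbers stand for stronger inhibition and higher numbers for weaker inhibition), compound 3 (`CCCCCCCCCCCCNC(=O)[C@@H]1CSC(c2ccc(OC)c(OC)c2)N1`) at 1600 nM stands level with compound 1 (`CCCCCCCCCCCCCCNC(=O)[C@@H]1CSC(c2cc(OC)c(OC)c(OC)c2)N1`) at 1600 nM as the lowest of the three numbers so far, while compound 2 (`CCCCCCCCCCNC(=O)[C@@H]1CSC(c2ccc(OC)c(OC)c2)N1`) lies higher at 6100 nM in the same read-out.

Within the data shown here, compound 4 (`CCCCCCCCCCCCCCNC(=O)[C@@H]1CSC(c2ccc(OC)c(OC)c2)N1`) lengthens the chain of compound 3, with ethyl in place of hydrogen on a saturated chain carbon, ten or more bonds along the chain from an amide-type nitrogen as its only structural change. Among the measured compounds shown here, the one measured step of the same kind is a 3.8-fold lower number from compound 2 to compound 3 (0.58 log units; beyond the scatter) and is modest but beyond the scatter. Compound 1 already carries the chain of compound 4, but on a different aryl part, so it gives only loose support. A single step does not establish a trend, and no data show whether the lowering continues at this chain length.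

A further lowering in this assay is expected, smaller than the measured step and possibly within the scatter. The expected change is a 1.6-fold lower number from compound 3 to compound 4 (0.20 log units; within the scatter) in this estimate. For compound 4 the estimated value is 1000 nM with an expected range of 420 nM to 2500 nM in this read-out.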

Compound 4, half-maximal inhibitory concentration: 800 nM
For compound 4 the middle estimate is 1.3-fold (0.10 log units) above the measured one; low and high end bracket the measured number.
By their numbers in this assay, from the lowest: compounds 4, 1 and 3 (each within the scatter of the next); then compound 2.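

In this assay, a second ethyl in place of hydrogen at this chain position gives a 2.0-fold lower number from compound 3 to compound 4 (0.30 log units; within the scatter), so this extension, unlike the earlier one, cannot be told from scatter, while the combined butyl change gives a 7.6-fold lower number from compound 2 to compound 4 (0.88 log units; beyond the scatter) and stays beyond it. The series also gains its first comparison on the aryl part with the chain held constant: hydrogen in place of methoxy on an aromatic carbon gives a 2.0-fold lower number from compound 1 to compound 4 (0.30 log units; within the scatter), a difference this read-out does not resolve. No measured evidence bears on the cause of these results.

Going by these compounds, whether a longer chain would keep the number level or shift it remains open. So does the reading of an amine or a carboxylic acid in place of the ethyl at this position.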